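Aryl amide variation in the benzylsulfonamide series

The compounds below may be only part of what the source reports. "The series", "measured", "known", "first", "only" and "open" are said of these compounds alone.

Compound 1 `Cc1ccc(S(=O)(=O)NCc2ccc(CNC(=O)c3c(Cl)cc(Cl)cc3Cl)cc2)cc1` gives 10 nM in an assay on MDA-MB-231 cells for binding affinity to C-X-C chemokine receptor type 4 (Homo sapiens), read by immunofluorescence and microscopy, with stated times of 10 min and 30 min; a higher number here means that more compound is needed for the effect, a lower number that less compound is needed. Compound 2 `Cc1ccc(S(=O)(=O)NCc2ccc(CNC(=O)c3cccc(Cl)c3)cc2)cc1` gives 100 nM, and compound 3 `O=C(NCc1ccc(CNS(=O)(=O)c2ccccc2)cc1)c1cccc(Cl)c1` gives 1000 nM, the highest of the three numbers; its nearest neighbour is compound 2 and its furthest is compound 1. The two measured steps are a 10-fold higher number from compound 1 to compound 2 (1.00 log units; beyond the scatter), with 3-chlorophenyl in place of 2,4,6-trichlorophenyl on a carbonyl carbon, and a 10-fold higher number from compound 2 to compound 3 (1.00 log units; beyond the scatter), with hydrogen in place of methyl on an aromatic carbon.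

Compound 4 `Cc1ccccc1C(=O)NCc1ccc(CNS(=O)(=O)c2ccccc2)cc1` is not yet measured. It differs from compound 3 by 2-methylphenyl in place of 3-chlorophenyl on a carbonyl carbon. Only the first step bears on this change, as it also exchanges the aryl group on the carbonyl carbon, and there the exchange gave a 10-fold higher number from compound 1 to compound 2 (1.00 log units; beyond the scatter). The second step concerns a different part of the molecule and does not inform this change. A further exchange of this ring, removing its remaining chlorine, is therefore expected to raise the number again, though less steeply, giving an expected step of a 2.5-fold higher number from compound 3 to compound 4 (0.40 log units; beyond the scatter). Compound 4 is estimated at 2500 nM, with a range from 800 nM to 8000 nM.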

Compound 4, effective concentration (reported as EC, without a stated level of effect): 1 nM
Compound 4: the middle estimate sits 2500-fold (3.40 log units) above what was measured, and the stated range ends above it.
By their numbers in this assay, from the lowest: compound 4; then compound 1; then compound 2; then compound 3.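

In this assay, 2-methylphenyl in place of 3-chlorophenyl on a carbonyl carbon gives a 1000-fold lower number from compound 3 to compound 4 (3.00 log units; beyond the scatter), a larger change than a 10-fold higher number from compound 1 to compound 2 (1.00 log units; beyond the scatter) and opposite in direction. Fewer chlorines on this ring therefore do not go with a higher number throughout the series: the fall in chlorine count from compound 1 to compound 2 fits that pattern, whereas compound 3 to compound 4 goes against it. Nothing available accounts for the size or direction of this step.

Among these compounds, the single exchange changes both the group and its place on the ring, so the contributions of losing the chlorine and gaining the methyl cannot be separated. Also open, going by these compounds, is whether a methoxy group or an amine on this ring would give a number like that of compound 4 or compound 3.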